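The source may report more compounds than this note shows. Statements on the series, on what has been measured and on what is new or still open speak of the compounds shown alone.

Compound 2 `FC(F)(F)c1ccc(-c2[nH]c(N3CCN(c4ncccc4C(F)(F)F)CC3)nc2Cl)cc1` is measured in a functional assay on CHO cells for antagonist activity at transient receptor potential cation channel subfamily V member 1 (Rattus norvegicus), read by calcium flux (a higher number here means a weaker inhibitor, a lower number a stronger inhibitor), at 160 nM. Of the two compounds with numbers, compound 2 has the higher one; its nearest neighbour is compound 1 `Fc1cc(-c2nc(N3CCN(c4ncccc4C(F)(F)F)CC3)[nH]c2-c2ccc(C(F)(F)F)cc2)cc(F)c1F`, and in this assay compound 1 gives 7 nM. Within the data shown here, the single step between them, a 23-fold higher number from compound 1 to compound 2 (1.36 log units; beyond the scatter), is the only measured guide available.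

Compound 3 `COC(=O)c1nc(N2CCN(c3ncccc3C(F)(F)F)CC2)[nH]c1-c1ccc(C(F)(F)F)cc1` has not yet been measured. It differs from compound 2 in one place: methoxycarbonyl in place of chloro on an aromatic carbon. Among the measured compounds shown here, nothing measured bears directly on a methoxycarbonyl at that carbon; the one step known, from the 3,4,5-trifluorophenyl to the chloro, went strongly toward a weaker inhibitor, but it concerns a different group. The expectation for compound 3 in this assay is therefore a loose one, centred close to compound 2 with room on either side, as a 1.6-fold higher number from compound 2 to compound 3 (0.19 log units; within the scatter). For compound 3 the estimated value is 250 nM, expected to fall between 50 nM and 1300 nM.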

Compound 3, half-maximal inhibitory concentration: 1170 nM
The estimate for compound 3 lay 4.7-fold (0.67 log units) below the measured number; the range from low to high includes it.
By their numbers in this assay, from the lowest: compound 1; then compound 2; then compound 3.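

Compound 3 shows that this carbon, next to the ring atom that bears a 4-(trifluoromethyl)phenyl group, responds strongly even when one non-ring group replaces another: the change from chloro to methoxycarbonyl gives a 7.3-fold higher number from compound 2 to compound 3 (0.86 log units; beyond the scatter) in this assay and is beyond the scatter. The full span at this one carbon is a 170-fold higher number from compound 1 to compound 3 (2.22 log units; beyond the scatter) and so is larger than the earlier step alone showed, with the 3,4,5-trifluorophenyl of compound 1 giving the lowest number of the three compounds. No measurement shown here explains this order.

Going by these compounds, whether the higher number belongs to methoxycarbonyl specifically remains open, since a carboxylic acid or a primary amide at this carbon could separate the effect of the methyl ester from that of the carbonyl. On these data alone, it also remains open whether an unsubstituted phenyl ring there would match compound 1.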